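Chalcone triazole series: macrophage tolerance, hexyl to 4-bromobenzyl

The source may hold more compounds than are shown below. What is called first, only, known or untested is meant among the compounds shown, and "the series" means these compounds.

Measured compounds:
- compound 1 `CCCCCCn1cc(COc2ccc(C(=O)/C=C/c3ccccc3)c(O)c2)nn1`: "not determined" (no result reported)
- compound 2 `C#CCOc1ccc(/C=C/C(=O)c2ccc(OCc3cn(CCCCCC)nn3)cc2O)cc1`: "not determined" (no result reported)
- compound 3 `CCCCCCn1cc(COc2ccc(C(=O)/C=C/c3c(F)cccc3Cl)c(O)c2)nn1`: > 100000 nM

Compound 1 has no number in an ADME assay on cells (Macrophage) for cytotoxicity, read by resazurin assay, with a stated time of 48 h; a higher number here means that more compound is tolerated, a lower number that less compound is tolerated. Compound 2 likewise reports no result in this assay. Compound 3 gives only a limit in this assay, > 100000 nM, which marks the edge of the measurement and not a value. Across the three compounds, one value sits at the limit of > 100000 nM in this assay, at which 1 of the 3 values shown sits, and the other two carry no number, so compound 1 cannot be placed against any measured neighbour.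

Compound 4 `O=C(/C=C/c1ccccc1)c1ccc(OCc2cn(Cc3ccc(Br)cc3)nn2)cc1O` is not yet measured. It differs from compound 1 by 4-bromophenyl in place of pentyl on a saturated chain carbon bound to an aromatic nitrogen.

Within the data shown here, no step between measured compounds exists, so the size of this change cannot be read from the series. The only measured entry, compound 3, sits at the limit, which points to tolerance in this assay staying high. The step from compound 1 to compound 4 is expected to remain within the scatter, with no direction beyond it. Compound 4 is estimated at 80000 nM, within 25000 nM to 200000 nM, with a fair chance that only a limit is again reported.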

Compound 4, half-maximal cytotoxic concentration: 71700 nM
The estimate for compound 4 lay 1.1-fold (0.05 log units) above the measured number; low and high end bracket the measured number.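

No new step can be read from this result: compound 4 cannot be paired with a number for compound 1, compound 2 or compound 3. The compounds shown leave open how far hexyl to 4-bromobenzyl shifts the read-out in this assay, and one entry remains only a limit: the limit of > 100000 nM in this assay, at which 1 of the 4 values shown sits.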